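The compounds below may be only part of what the source reports. "The series", "measured", "known", "first", "only" and "open" are said of these compounds alone.

In an ADME assay on L6 cells (Rattus norvegicus) for cytotoxicity (a lower number here means a stronger inhibitor, a higher number a weaker inhibitor), compound 1 `Cc1ccc(S(=O)(=O)N2c3ccccc3CCC2C)cc1` gives 4900 nM, while compound 2 `CC1CCc2ccccc2N1S(=O)(=O)c1ccc(F)cc1` gives 67600 nM, the higher of the two numbers. The change to compound 3 `CC1CCc2ccccc2N1S(=O)(=O)c1ccc(Br)cc1` is bromo in place of fluoro on an aromatic carbon, para to a large group (bromo in place of fluoro on an aromatic carbon). For the measured compounds named here, only one measured step bears on this place: a 14-fold higher number from compound 1 to compound 2 (1.14 log units; beyond the scatter), which is large, beyond the scatter, and comes from fluoro in place of methyl. Going by the values given here, no bromo compound has been measured, so this single step is a thin guide. Given a 14-fold higher number from compound 1 to compound 2 (1.14 log units; beyond the scatter), a large step is expected in this assay, towards a lower number. The estimated step is a 5.6-fold lower number from compound 2 to compound 3 (0.75 log units; beyond the scatter). For compound 3 the estimated value is 12000 nM, with an expected range of 3500 nM to 40000 nM.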

Compound 3, half-maximal inhibitory concentration: 7360 nM
Estimate against measurement, compound 3: 1.6-fold (0.21 log units) above; the measured number falls inside the stated range.
By their numbers in this assay, from the lowest: compounds 1 and 3 (each within the scatter of the next); then compound 2.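

Going from 4-fluorophenyl to 4-bromophenyl gives a 9.2-fold lower number from compound 2 to compound 3 (0.96 log units; beyond the scatter) in this assay and shows that the high number of compound 2 does not extend to every halogen at this position. For the compounds shown here, with a 1.5-fold higher number from compound 1 to compound 3 (0.18 log units; within the scatter) bromo and methyl cannot be told apart here, which leaves fluoro as the one group of the three that stands clearly apart. No measurement at hand speaks to what sets fluoro apart from the other two groups.

From the compounds shown here alone, whether chloro would fall with bromo and methyl or with fluoro remains open, as does the outcome for a methoxy group, an amine or a carboxylic acid in the same place. Going by these compounds, all three compounds share one core, so whether this order of groups survives a change elsewhere in the core also remains open.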